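The compounds below may be only part of what the source reports. "The series", "measured", "known", "first", "only" and "open" are said of these compounds alone.

In a functional assay on HL-60 cells (Homo sapiens) for inhibition, read by CCK-8 assay, with a stated time of 48 h (a higher number here means a weaker inhibitor, a lower number a stronger inhibitor), compound 1 `COc1ccc(Oc2ccccc2-c2ccsc2S(=O)(=O)NCCNC(=S)Nc2cc(C(F)(F)F)cc(C(F)(F)F)c2)cc1OC` gives 2800 nM, while compound 2 `CC(C)c1ccc(Oc2ccc(O)c(O)c2)c(-c2ccsc2S(=O)(=O)NCCNC(=S)Nc2cc(C(F)(F)F)cc(C(F)(F)F)c2)c1` gives 8200 nM, the higher of the two numbers by a gap beyond the usual scatter. Compound 3 `O=S(=O)(NCCNC(=S)Nc1cc(C(F)(F)F)cc(C(F)(F)F)c1)c1sccc1-c1ccccc1Oc1ccc(O)c(O)c1` differs from compound 2 by hydrogen in place of isopropyl on an aromatic carbon. Going by the values given here, no measured pair shows this change alone. Compound 1 also carries no isopropyl and gives 2800 nM, though it differs in other ways too. A small step towards a lower number is expected, an estimated 1.6-fold lower number from compound 2 to compound 3 (0.21 log units; within the scatter). Compound 3 is estimated at 5000 nM, with an expected range of 1900 nM to 13000 nM.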

Compound 3, half-maximal inhibitory concentration: 4300 nM
Compound 3: the middle estimate sits 1.2-fold (0.07 log units) above what was measured; measured number inside the range.
By their numbers in this assay, from the lowest: compounds 1, 3 and 2 (each within the scatter of the next, the first and the last beyond it).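

Hydrogen in place of isopropyl on this aromatic carbon gives a 1.9-fold lower number from compound 2 to compound 3 (0.28 log units; within the scatter), so in this assay the isopropyl can be lost without a shift beyond the scatter. The first single-change view of the oxygen substituent, 3,4-dihydroxyphenyl in place of 3,4-dimethoxyphenyl, gives a 1.5-fold higher number from compound 1 to compound 3 (0.19 log units; within the scatter), so this assay does not separate those two groups either. Nothing available explains either step. Going by these compounds, whether an amine or a carboxylic acid on this same aromatic carbon would move the number beyond the scatter remains open.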